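Hydrogen in place of fluoro at the limit of growth inhibition

A few compounds are considered here, and "the series" means these few. Any claim that something is new, unique, unknown or untested is made for them only; others in the source may bear on it.

Compound 1 `O=C(CCN1C(=O)CSc2ccccc21)NCCCN1CCN(c2ccc([N+](=O)[O-])cc2)CC1` carries a 4-nitrophenyl group on an amine nitrogen in a ring. In a functional assay (MiaPaCa cells, Homo sapiens) for inhibition, read by sulforhodamine B assay, with a stated time of 48 h (on this read-out lower numbers stand for stronger inhibition of growth and higher numbers for weaker inhibition of growth), compound 1 gives > 100000 nM, which is a limit of the assay and not a number. Compound 2 `O=C(CCN1C(=O)CSc2ccccc21)NCCCN1CCN(c2ccccc2F)CC1` differs from it by 2-fluorophenyl in place of 4-nitrophenyl on that amine nitrogen. In this assay compound 2 gives > 100000 nM, again a limit of the assay rather than a number. The step that the two limits leave unreadable from compound 1 to compound 2 therefore cannot be read, and compound 2 stands at the limit of > 100000 nM in this assay, at which 2 of the 2 values shown sit, with no measured value anywhere on the shared core to set a scale.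

Compound 3 `O=C(CCN1C(=O)CSc2ccccc21)NCCCN1CCN(c2ccccc2)CC1` is the next member: hydrogen in place of fluoro on an aromatic carbon. Among the measured compounds shown here, no measured step in this assay carries a readable size, so the only guide is that both neighbours sit at the limit. On that basis compound 3 is expected to stay at the limit as well, with an estimated value of 150000 nM, lying between 30000 nM and 800000 nM. The implied step that the limit leaves unreadable from compound 2 to compound 3 is thus expected to show no change beyond the scatter.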

Compound 3, concentration for 50% growth inhibition: > 100000 nM
Compound 3: no number, only a limit; the forecaster's own chance of this, stated with the estimate: 85%; the middle value does not contradict the limit.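

In this assay compound 3 gives > 100000 nM as a limit of the assay and not a number. The steps among compound 1, compound 2 and compound 3 therefore cannot be read, and all three stay at the same limit: the limit of > 100000 nM in this assay, at which 3 of the 3 values shown sit. The compounds shown leave open whether any change on the shared core brings growth inhibition to a measurable value.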